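The source may report more compounds than this note shows. Statements on the series, on what has been measured and on what is new or still open speak of the compounds shown alone.

Compound 1 `CN(C)c1nc(N)nc2c1ncn2/C=C1/CC1(CO)CO` gives in an ADME assay on Akata cells (Homo sapiens) for cytotoxicity, with a stated time of 7 days (a lower number here means that less compound is tolerated, a higher number that more compound is tolerated), only a limit of the measurement, > 24000 nM. Compound 2 `CCCCCOc1nc(N)nc2c1ncn2/C=C1/CC1(CO)CO` gives in this assay only a limit, > 20000 nM. Compound 3 `CC(C)Sc1nc(N)nc2c1ncn2/C=C1/CC1(CO)CO` gives in this assay only a limit, > 20000 nM.

So compound 1 stands at no number in this assay but at a limit, and the same holds for the other two measured compounds. Compound 2 and compound 3 sit at the limit of > 20000 nM in this assay, at which 2 of the 3 values shown sit. Compound 1 sits at the limit of > 24000 nM in this assay, at which 1 of the 3 values shown sits. None of the three could be told apart.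

Compound 4 `CCCOc1nc(N)nc2c1ncn2/C=C1/CC1(CO)CO` has not yet been measured in this assay. It differs from compound 1 in a single place: propoxy in place of dimethylamino on an aromatic carbon. Going by the values given here, three measured steps bear on this exchange: a step that the two limits leave unreadable from compound 1 to compound 2, a step that the two limits leave unreadable from compound 1 to compound 3 and a step that the two limits leave unreadable from compound 2 to compound 3. Each of them joins two limits, so none of them can be read, and none shows a step beyond the scatter in either direction. Nothing in these data gives a reason to expect the propoxy group to behave differently from the pentyloxy or isopropylsulfanyl groups, so in this assay the step of an at least 1.2-fold lower number from compound 1 to compound 4 (0.07 log units; that floor lies within the scatter) is expected to be none beyond the scatter. Compound 4 is therefore estimated at 20000 nM, within 8000 nM to 50000 nM, and most likely reported again only as a limit.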

Compound 4, half-maximal cytotoxic concentration: > 20000 nM
Compound 4: a limit, no number; the forecaster's own chance of this, stated with the estimate: 85%; the middle value lies on the limit itself.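

Compound 4 gives only a limit in this assay, > 20000 nM. The steps joining compound 4 to compound 1, compound 2 and compound 3 each link two limits, so none of them can be read. The four compounds leave open what concentration of each gives the half-maximal cytotoxic effect, and whether the groups exchanged on the shared core differ at all.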